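Naphthalen-1-yl on the sulfur: notes towards compound 3

A few compounds are considered here, and "the series" means these few. Any claim that something is new, unique, unknown or untested is made for them only; others in the source may bear on it.

Measured so far:
- compound 1 `COc1ccc(SCc2ccc(/C=C/C(=O)Nc3ccccc3N)cc2)cc1OC`: 10.1%
- compound 2 `Nc1ccccc1NC(=O)/C=C/c1ccc(CSc2ccc(F)cc2)cc1`: 7.09%

Within the data shown here, in a functional assay on HeLa cells (Homo sapiens) for inhibition, read by CCK-8 assay, with a stated time of 72 h, tested at 2 uM (on this read-out lower numbers stand for less inhibition of growth and higher numbers for more inhibition of growth at the one concentration tested), compound 2 gives 7.09%, which lies within the scatter of compound 1, the only other compound measured. The next compound, compound 3 `Nc1ccccc1NC(=O)/C=C/c1ccc(CSc2cccc3ccccc23)cc1`, has naphthalen-1-yl in place of 4-fluorophenyl on a sulfur. Among the measured compounds shown here, one measured step bears on this place: a number 3 percentage points lower from compound 1 to compound 2 (within the scatter). That step stayed within the scatter, but it is the only one available, and neither measured compound carries naphthalen-1-yl. No step beyond the scatter is therefore expected in this assay, though this rests on thin evidence. The expected change is a number 2.9 percentage points higher from compound 2 to compound 3 (within the scatter). For compound 3 the estimated value is 10%, with an expected range of 2% to 25%.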

Compound 3, percent growth inhibition at one concentration: 20.6%
Compound 3: middle estimate off by 10.6 percentage points, on the low side; measured number inside the range.
By their numbers in this assay, from the lowest: compounds 2 and 1 (each within the scatter of the next); then compound 3.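

In this assay the group on the sulfur proves able to shift the read-out: naphthalen-1-yl gives a number 13.5 percentage points higher from compound 2 to compound 3 (beyond the scatter) and a number 10.5 percentage points higher from compound 1 to compound 3 (beyond the scatter), whereas 4-fluorophenyl and 3,4-dimethoxyphenyl stay within the scatter of each other. Among these three compounds, only the group with 2 six-membered aromatic rings of carbon only stands apart, so the place on the sulfur accepts a larger group than either single-ring group without loss of growth inhibition. No measurement on hand explains the step.

Three groups cannot separate the effect of the second ring from that of how the group is attached, a question that naphthalen-2-yl or a benzyl group on the sulfur would address. A basic amine such as a dimethylamino group on the ring, or a carboxylic acid there, remains an open case for this place.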